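Trimming Ethyl to Methyl at the Assay Limit

The compounds below may be only part of what the source reports. "The series", "measured", "known", "first", "only" and "open" are said of these compounds alone.

In a functional assay on MDA-MB-231 cells (Homo sapiens) for inhibition, read by MTT assay, with a stated time of 48 h (a higher number here means a weaker inhibitor, a lower number a stronger inhibitor), compound 1 `CCn1c(/C=C2\SC(=O)N(CC(=O)N3CCc4cc(OC)c(OC)cc4C3)C2=O)nc2ccccc21` gives > 50000 nM, which is a limit of the assay and not a number. Compound 2 `CC(C)n1c(/C=C2\SC(=O)N(CC(=O)N3CCCCC3)C2=O)nc2ccccc21` reads > 50000 nM, also a limit. Compound 3 `CC1CN(C(=O)CN2C(=O)S/C(=C\c3nc4ccccc4n3C)C2=O)CC(C)O1` reads > 50000 nM, a limit once more. So all three measured compounds sit in the same place: the limit of > 50000 nM in this assay, at which 3 of the 3 values shown sit.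

Compound 4 `COc1cc2c(cc1OC)CN(C(=O)CN1C(=O)S/C(=C\c3nc4ccccc4n3C)C1=O)CC2` keeps the rest of compound 1 and changes one small group (hydrogen in place of methyl on a saturated chain carbon bound to an aromatic nitrogen). In words, hydrogen comes in place of methyl on a saturated chain carbon bound to an aromatic nitrogen, so ethyl becomes methyl. For the measured compounds named here, no measured pair shows what this change does. Compound 3 also carries the 1-methyl-1H-benzimidazol-2-yl group, and its reading of > 50000 nM is a limit too. The expected step in this assay is therefore none beyond the usual scatter, estimated as a step that the limit leaves unreadable from compound 1 to compound 4. The most likely outcome is another limit. If a number is reported, the estimated value for compound 4 is 60000 nM, with an expected range of 30000 nM to 120000 nM.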

Compound 4, half-maximal inhibitory concentration: 36000 nM
The estimate for compound 4 lay 1.7-fold (0.22 log units) above the measured number; the range from low to high includes it.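

With ethyl trimmed to methyl, this assay gives its first real number, and the change reads as an at least 1.3-fold lower number from compound 1 to compound 4 (0.14 log units; that floor lies within the scatter); that figure is only a floor, and it lies within the scatter, so it does not establish a gain in potency. Methyl at this position does not by itself bring a numerical reading: compound 3, which also carries the 1-methyl-1H-benzimidazol-2-yl group, gives > 50000 nM, which is a limit. With only compound 4 reading as a number, the series offers almost nothing to compare: the limit of > 50000 nM in this assay, at which 3 of the 4 values shown sit.

The compounds shown leave open how a bare hydrogen, a benzyl group or a 2-hydroxyethyl chain in this place would read with the rest of compound 4. They also leave open whether the true step from ethyl to methyl is larger than its floor.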